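The source may report more compounds than this note shows. Statements on the series, on what has been measured and on what is new or still open speak of the compounds shown alone.

Three compounds have been measured in a functional assay on HeLa cells (Homo sapiens) for cytotoxicity, read by MTT assay; a higher number here means a weaker inhibitor, a lower number a stronger inhibitor:
compound 1, `CCC(C)(O)CC(=O)O[C@H](CC=C(C)C)C1=CC(=O)c2c(O)ccc(O)c2C1=O`: 25200 nM
compound 2, `CC[C@@](C)(O)CC(=O)O[C@H](CC=C(C)C)C1=CC(=O)c2c(O)ccc(O)c2C1=O`: 17900 nM
compound 3, `COCCO[C@H](CC=C(C)C)C1=CC(=O)c2c(O)ccc(O)c2C1=O`: 62400 nM

Compound 1 stands second highest of these three numbers. The nearest value to it appears in a 1.4-fold lower number from compound 1 to compound 2 (0.15 log units; within the scatter), the furthest in a 2.5-fold higher number from compound 1 to compound 3 (0.39 log units; beyond the scatter). Compound 4, `CC(C)=CC[C@@H](OC(=O)CC(C)(O)C(C)C)C1=CC(=O)c2c(O)ccc(O)c2C1=O`, differs from compound 1 by methyl in place of hydrogen on a saturated chain carbon bound to two saturated chain carbons. Neither measured step matches this change: the step from compound 1 to compound 2 alters only how a stereocentre is drawn, and the step from compound 1 to compound 3 replaces the whole (2-hydroxy-2-methylbutyl)carbonyl group. Here the group is kept and gains a methyl on a saturated chain carbon, so no step beyond the scatter is expected in this assay. The expected change is a 1.1-fold lower number from compound 1 to compound 4 (0.04 log units; within the scatter). Compound 4 is estimated at 23000 nM, within 10000 nM to 50000 nM.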

Compound 4, half-maximal inhibitory concentration: 27700 nM
Estimate against measurement, compound 4: 1.2-fold (0.08 log units) below, and the stated range covers the measured number.
By their numbers in this assay, from the lowest: compounds 2, 1 and 4 (each within the scatter of the next); then compound 3.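

In this assay, methyl in place of hydrogen on a saturated chain carbon bound to two saturated chain carbons, which turns ethyl into isopropyl, leaves the number within the scatter of both neighbouring compounds (a 1.1-fold higher number from compound 1 to compound 4 (0.04 log units; within the scatter); a 1.5-fold higher number from compound 2 to compound 4 (0.19 log units; within the scatter)). The enlarged (2-hydroxy-2,3-dimethylbutyl)carbonyl group still stands apart from 2-methoxyethyl (a 2.3-fold lower number from compound 3 to compound 4 (0.35 log units; beyond the scatter)). Nothing given here explains these steps. Going by these compounds, whether a longer chain, a phenyl ring or an amine at this carbon would shift the number remains open.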